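The compounds below may be only part of what the source reports. "The series", "measured", "known", "first", "only" and "open" are said of these compounds alone.

In an ADME assay on HepG2 2.2.15 cells (Homo sapiens) for cytotoxicity, read by luminescence, with a stated time of 3 days (a higher number here means that more compound is tolerated, a lower number that less compound is tolerated), compound 1 `O=C(Nc1ccc(F)c(Cl)c1)c1ccc(F)c(S(=O)(=O)N2CCSCC(O)C2)c1` gives 19000 nM. Two close relatives carry an eight-membered non-aromatic ring on the sulfonyl sulfur instead of the seven-membered one: compound 2 `O=C(Nc1ccc(F)c(Cl)c1)c1ccc(F)c(S(=O)(=O)N2CCCCCC(O)C2)c1` gives 11000 nM, and compound 3 `O=C(Nc1ccc(F)c(Cl)c1)c1ccc(F)c(S(=O)(=O)N2CCCCC(O)CC2)c1` gives 24000 nM. Compound 1 has the middle number of the three, and only the outer pair is separated beyond the scatter, by a 2.2-fold higher number from compound 2 to compound 3 (0.34 log units; beyond the scatter).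

Compound 4 `O=C(Nc1ccc(F)c(Cl)c1)c1ccc(F)c(S(=O)(=O)N2CCOC[C@H](O)C2)c1` has not been measured yet. It keeps the shared core and differs from compound 1 only in the group on the sulfonyl sulfur: a group of 8 heavy atoms (5 carbon, 1 nitrogen, 2 oxygen; one seven-membered non-aromatic ring with 2 hetero atoms) in place of a group of 8 heavy atoms (5 carbon, 1 nitrogen, 1 oxygen, 1 sulfur; one seven-membered non-aromatic ring with 2 hetero atoms), on a sulfonyl sulfur. The entering group is named 6-hydroxy-1,4-oxazepan-4-yl, so the ring stays seven-membered.

Among the compounds with values here, no measured step makes exactly this exchange, so the evidence is indirect. The nearest guides are the two ring exchanges that start from compound 1. Because a 1.7-fold lower number from compound 1 to compound 2 (0.24 log units; within the scatter) and a 1.3-fold higher number from compound 1 to compound 3 (0.10 log units; within the scatter) both stayed within the scatter, no step beyond the scatter is expected for compound 4 in this assay. The expected step is a 1.2-fold higher number from compound 1 to compound 4 (0.06 log units; within the scatter). For compound 4 the estimated value is 22000 nM, with an expected range of 11000 nM to 45000 nM.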

Compound 4, half-maximal cytotoxic concentration: 19000 nM
Compound 4: middle estimate off by 1.2-fold (0.06 log units), on the high side; low and high end bracket the measured number.
By their numbers in this assay, from the lowest: compounds 2, 1, 4 and 3 (each within the scatter of the next, the first and the last beyond it).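

In this assay, within the data shown here, placing oxygen where compound 1 has sulfur, with the seven-membered ring on the sulfonyl sulfur kept, gives no change at the digits printed from compound 1 to compound 4 (within the scatter); this is the first direct look at that ring hetero atom, and this single exchange leaves the read-out unmoved. Compound 4 also stays within the scatter of both eight-membered relatives, with a 1.3-fold lower number from compound 3 to compound 4 (0.10 log units; within the scatter) and a 1.7-fold higher number from compound 2 to compound 4 (0.24 log units; within the scatter), although those two relatives are separated beyond the scatter by a 2.2-fold higher number from compound 2 to compound 3 (0.34 log units; beyond the scatter). Nothing in the data given explains why sulfur and oxygen read alike here.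

The compounds shown leave open whether the other arrangement at the defined stereocentre of 6-hydroxy-1,4-oxazepan-4-yl would read the same, and whether the hydroxy group matters at all, since every ring here carries one. They also leave open what would happen with a basic amine nitrogen in the ring in place of oxygen or sulfur, or with a carboxylic acid in place of the hydroxy group, as either would bring a charge that none of these four compounds has.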